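A few compounds are considered here, and "the series" means these few. Any claim that something is new, unique, unknown or untested is made for them only; others in the source may bear on it.

In an assay on LX2 cells for inhibition of COL1A1 promoter (Homo sapiens), read by a luciferase reporter, with a stated time of 24 h, tested at 50 uM (on this read-out lower numbers stand for a weaker effect and higher numbers for a stronger effect at the one concentration tested), compound 1 `Cc1ccc(-n2cc(C(=O)Nc3cc(F)cc(F)c3)c(=O)c3ccc(N(C)C)nc32)cc1OCCCCCCC[N+]1(C)CCCC1` gives 55.9%. Compound 2 `CN(C)c1ccc2c(=O)c(C(=O)Nc3cc(F)cc(F)c3)cn(-c3ccc(Cl)c(OCCCCCCC[N+]4(C)CCCC4)c3)c2n1` gives 76.1% in this assay. The two differ by chloro in place of methyl on an aromatic carbon, and the measured step is a number 20.2 percentage points higher from compound 1 to compound 2 (beyond the scatter). Compound 3 `Cc1ccc(-n2cc(C(=O)Nc3cc(F)cc(F)c3)c(=O)c3ccc(N(C)C)nc32)cc1OCCCCCCC[N+](C)(C)C1CCCCC1` gives 61.7% in this assay. Its core differs from the core of compound 1 by a group of 9 heavy atoms (8 carbon, 1 nitrogen; one six-membered non-aromatic ring of carbon only) in place of a group of 6 heavy atoms (5 carbon, 1 nitrogen; one five-membered non-aromatic ring with 1 hetero atom), on a saturated chain carbon, seven bonds along the chain from an oxygen on an aromatic ring, and the step between them is a number 5.8 percentage points higher from compound 1 to compound 3 (within the scatter). Compound 4 `CN(C)c1ccc2c(=O)c(C(=O)Nc3cc(F)cc(F)c3)cn(-c3ccc(Cl)c(OCCCCCCC[N+](C)(C)C4CCCCC4)c3)c2n1` has not yet been measured. It differs from compound 3 by chloro in place of methyl on an aromatic carbon, the same change already seen between the two measured compounds, at a place described in the same words. For the measured compounds named here, a step of similar size is expected, a number 17.3 percentage points higher from compound 3 to compound 4 (beyond the scatter), because a number 20.2 percentage points higher from compound 1 to compound 2 (beyond the scatter) is the only measured instance of this change and rests on a single pair. Compound 4 is therefore estimated at 79%, between 66% and 90%.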

Compound 4, a percentage reported as inhibition, at one concentration (the size of the read-out at that concentration, not a potency): 81.4%
Beside the measured number, compound 4's estimate is 2.4 percentage points below it; the measured number falls inside the stated range.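

In this assay chloro in place of methyl on an aromatic carbon gives a number 19.7 percentage points higher from compound 3 to compound 4 (beyond the scatter) and so carries over from one core to the other: the same change on two cores in this assay, a number 20.2 percentage points higher (beyond the scatter) from compound 1 to compound 2 and a number 19.7 percentage points higher (beyond the scatter) from compound 3 to compound 4, 0.5 percentage points apart, within the scatter of two such steps. Exchanging the group at the end of the chain gives a number 5.3 percentage points higher from compound 2 to compound 4 (within the scatter) and reads the same whether the aromatic carbon bears methyl or chloro: the same change on two cores in this assay, a number 5.8 percentage points higher (within the scatter) from compound 1 to compound 3 and a number 5.3 percentage points higher (within the scatter) from compound 2 to compound 4, 0.5 percentage points apart, within the scatter of two such steps. Within these compounds the two changes therefore behave as independent of each other, but this rests on only two pairs at a single concentration and does not show that the chloro step would hold on a different core, nor why it arises.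

Still open, as far as these compounds go, is whether fluoro, bromo or methoxy at that aromatic carbon would give a similar step. Also open, from the compounds shown here alone, is whether the step would survive on a shorter or longer chain.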